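Moving the triple bond one carbon out on the ester

The compounds below may be only part of what the source reports. "The series", "measured", "known", "first", "only" and "open" are said of these compounds alone.

Compound 1, `CCn1c(C(=O)N(C)CCC#N)ccc1C(CC)(CC)c1ccc(OCC(O)C(C)(C)C)c(C)c1`: 1960 nM
Compound 2, `C#CC(C)OC(=O)c1ccc(C(CC)(CC)c2ccc(OCC(O)C(C)(C)C)c(C)c2)n1CC`: 200 nM

The two measured compounds share one core and differ only in the group on the carbonyl carbon. In an assay on HL-60 cells for agonist activity at vitamin D3 receptor (Homo sapiens), read by microscopy, with a stated time of 96 h (on this read-out higher numbers stand for an effect only at larger amounts of compound and lower numbers for an effect already at smaller amounts), compound 1 gives 1960 nM, and compound 2 gives 200 nM, the lowest of the two numbers shown. The step of a 9.8-fold lower number from compound 1 to compound 2 (0.99 log units; beyond the scatter) describes that change from an amide to an ester.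

Compound 3, `C#CCCOC(=O)c1ccc(C(CC)(CC)c2ccc(OCC(O)C(C)(C)C)c(C)c2)n1CC`, keeps the ester and has not yet been measured. It differs from compound 2 only in how the chain on the ester oxygen is put together: but-3-yn-1-yl in place of 1-methylprop-2-yn-1-yl on an oxygen next to a carbonyl group. Within the data shown here, the one measured step bears only loosely on this change, since it swapped the whole group on the carbonyl carbon rather than rearranging a chain of the same atoms. Nothing measured here tells how the shape of that chain matters. The expected outcome for compound 3 is therefore a number close to that of compound 2, with a step of a 1.3-fold higher number from compound 2 to compound 3 (0.10 log units; within the scatter) not beyond the scatter. Compound 3 is estimated at 250 nM, in a range from 80 nM to 800 nM.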

Compound 3, half-maximal effective concentration: 1030 nM
Estimate against measurement, compound 3: 4.1-fold (0.61 log units) below, and the stated range ends below it.
By their numbers in this assay, from the lowest: compound 2; then compounds 3 and 1 (each within the scatter of the next).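

In this assay, compounds 2 and 3 hold the same atoms joined differently, yet there is a 5.2-fold higher number from compound 2 to compound 3 (0.71 log units; beyond the scatter) on moving from 1-methylprop-2-yn-1-yl to but-3-yn-1-yl, so on this oxygen next to a carbonyl group the way the chain is put together matters, not just the presence of an ester. Being an ester is therefore not enough to give the low number of compound 2: with a 1.9-fold lower number from compound 1 to compound 3 (0.28 log units; within the scatter) as the only difference, the ester compound 3 cannot be told apart from the amide compound 1 in this assay. No measured evidence here explains why rearranging the same four carbons shifts the number.

The two chains differ both in the methyl branch and in where the triple bond sits, so the compounds shown leave open which of these features accounts for the step. A prop-2-yn-1-yl ester, with the triple bond but no branch, and a saturated 1-methylpropyl ester, with the branch but no triple bond, would pull these two features apart.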